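Methoxy for trifluoromethyl: working notes on compound 4

The source may report more compounds than this note shows. Statements on the series, on what has been measured and on what is new or still open speak of the compounds shown alone.

Going by the values given here, in an ADME assay on HS27 cells (Homo sapiens) for antiproliferative activity, read by sulforhodamine B assay, with a stated time of 48 h (on this read-out lower numbers stand for stronger inhibition and higher numbers for weaker inhibition), compound 1 `O=C(O)c1cc2ccc(-c3ccc(C(F)(F)F)cc3)cc2n1O` gives 68000 nM, the only number so far. For compound 2 `O=C(O)c1cc2ccc(-c3cccc4ccccc34)cc2n1O` the result is a limit of the assay, > 100000 nM. For compound 3 `O=C(O)c1cc2ccc(-c3ccc4ccccc4c3)cc2n1O` the result is also a limit, > 100000 nM. The remaining picture is the limit of > 100000 nM in this assay, at which 2 of the 3 values shown sit.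

Compound 4 `COc1ccc(-c2ccc3cc(C(=O)O)n(O)c3c2)cc1` has methoxy in place of trifluoromethyl on an aromatic carbon, para to a large group (methoxy in place of trifluoromethyl on an aromatic carbon). Among the compounds with values here, no measured step covers this change. In this assay little change beyond the usual scatter is expected, with a slight lean towards weaker inhibition, given compound 1 at 68000 nM. The expected step is a 1.3-fold higher number from compound 1 to compound 4 (0.10 log units; within the scatter). For compound 4 the estimated value is 85000 nM, with an expected range of 40000 nM to 160000 nM.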

Compound 4, half-maximal inhibitory concentration: > 100000 nM
Compound 4 ended at the assay's limit; the forecaster's own chance of this, stated with the estimate: 40%; middle value at least 1.1-fold (0.07 log units) away from the limit.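

In this assay, methoxy in place of trifluoromethyl para to a large group gives an at least 1.4-fold higher number from compound 1 to compound 4 (0.16 log units; that floor lies within the scatter), the first step measured in the series, and it can be read only as a floor. Going by these compounds, compound 4 gives > 100000 nM, a limit of the assay and not a number, so the true size of the step remains unknown. Compound 1 remains the only compound with a number rather than a limit: the limit of > 100000 nM in this assay, at which 3 of the 4 values shown sit.

On these data alone, whether an amine or a nitrile at this place would give a number clear of the limit stays open. The compounds shown also leave open how far methoxy and trifluoromethyl really differ here.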